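The compounds below may be only part of what the source reports. "The series", "measured", "known", "first", "only" and "open" are said of these compounds alone.

In a functional assay on KB cells (Homo sapiens) (on this read-out higher numbers stand for an effect only at larger amounts of compound and lower numbers for an effect already at smaller amounts), compound 1 `COc1ccc2c(=O)cc(-c3ccccc3)sc2c1` gives 5.5 ug/mL, compound 2 `COc1cc2sc(-c3ccccc3)cc(=O)c2cc1OC` gives 4.23 ug/mL and compound 3 `CC(=O)Oc1cc2sc(-c3ccccc3)cc(=O)c2cc1OC(C)=O` gives 5.5 ug/mL. Compound 2 lies within the scatter of both other compounds, so no order can be read among the three.

Compound 4 `COc1cccc(-c2cc(=O)c3cc(OC)c(OC)cc3s2)c1` keeps the core of compound 2 and differs at one place: methoxy in place of hydrogen on an aromatic carbon. The change is methoxy in place of hydrogen on an aromatic carbon. One measured step is of the same kind, though at another place on the molecule: a 1.3-fold lower number from compound 1 to compound 2 (0.11 log units; within the scatter). Among the measured compounds shown here, this single precedent stays within the scatter and gives no direction, and no measured compound carries a substituent at the place changed in compound 4. No shift beyond the scatter is therefore expected in this assay, with the direction left open. The estimated size is a 1.1-fold higher number from compound 2 to compound 4 (0.03 log units; within the scatter). Compound 4 is expected at about 4.5 ug/mL, with an estimated range of 2.2 ug/mL to 9.5 ug/mL.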

Compound 4, concentration for half-maximal effect: 5.5 ug/mL
Compound 4: middle estimate off by 1.2-fold (0.09 log units), on the low side; the measured number falls inside the stated range.
By their numbers in this assay, from the lowest: compounds 2, 1, 3 and 4 (each within the scatter of the next).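

In this assay, methoxy in place of hydrogen on an aromatic carbon of the six-membered aromatic ring of carbon only, meta to a large group, gives a 1.3-fold higher number from compound 2 to compound 4 (0.11 log units; within the scatter). Among the compounds shown here, the earlier compounds carried no substituent at this place, so this is the first reading there, and it stays within the scatter, as does the methoxy step at the other place, a 1.3-fold lower number from compound 1 to compound 2 (0.11 log units; within the scatter). The data offer no measurement that bears on this result.

From the compounds shown here alone, whether an amine, a carboxylic acid or a longer chain at this place would move the number beyond the scatter remains open. Also open, going by these compounds, is whether any change to the shared core can separate compounds in this assay, since the four compounds, taken in order, each lie within the scatter of the next.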